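The source may report more compounds than this note shows. Statements on the series, on what has been measured and on what is new or still open speak of the compounds shown alone.

Measured compounds in an ADME assay on Vero cells (Chlorocebus sabaeus) for cytotoxicity; a higher number here means that more compound is tolerated, a lower number that less compound is tolerated:
compound 1 `O=C(O)c1cccc(-c2ccc(/C=C3\S/C(=N\c4ccc(F)cc4)N(c4ccc(F)cc4)C3=O)o2)c1` gives > 200000 nM
compound 2 `O=C(O)c1cccc(-c2ccc(/C=C3\S/C(=N\c4ccccc4)N(c4ccc(Cl)cc4)C3=O)o2)c1` gives > 200000 nM
compound 3 `O=C(O)c1cccc(-c2ccc(/C=C3\S/C(=N\c4ccc(Cl)cc4)N(c4ccccc4)C3=O)o2)c1` gives > 200000 nM

The value of compound 1 is a limit of the assay, not a number. The value of compound 2 is likewise a limit. Among the measured compounds shown here, the value of compound 3 is also a limit, so compound 3 stands at the limit of > 200000 nM in this assay, at which 3 of the 3 values shown sit, together with the other two, and no step between measured compounds can be read.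

Compound 4 `O=C(O)c1cccc(-c2ccc(/C=C3\S/C(=N\c4ccc(Cl)cc4)N(c4ncccc4F)C3=O)o2)c1` differs from compound 3 by 3-fluoropyridin-2-yl in place of phenyl on an amide-type nitrogen in a ring. Since every shown value sits at the limit, the step of a number no higher from compound 3 to compound 4 (the limit leaves the size open) is expected to be none beyond the scatter in this assay. Compound 4 is estimated at 200000 nM, in a range from 100000 nM to 400000 nM, most likely reported again as a limit.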

Compound 4, half-maximal cytotoxic concentration: > 200000 nM
Compound 4: a limit, no number; the forecaster's own chance of this, stated with the estimate: 85%; the middle value sits exactly at the limit.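

In this assay no step can be read from compound 3 to compound 4, as both values are limits and not numbers: the limit of > 200000 nM in this assay, at which 4 of the 4 values shown sit.

The compounds shown leave open whether any change on the shared core gives a readable number in this assay.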